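Swapping Methyl for Bromo in a Growth Inhibitor Series

A few compounds are considered here, and "the series" means these few. Any claim that something is new, unique, unknown or untested is made for them only; others in the source may bear on it.

Measured in a functional assay on KM12 cells (Homo sapiens) for antiproliferative activity; a lower number here means a stronger inhibitor of growth, a higher number a weaker inhibitor of growth:
- Compound 1 `Oc1ccc(-c2nc3ccccc3s2)cc1O`: 15600 nM
- Compound 2 `COc1ccc(-c2nc3ccccc3s2)cc1OC`: 74200 nM
- Compound 3 `COc1ccc(-c2nc3cc(F)ccc3s2)cc1C`: 18600 nM

Compound 3, at 18600 nM, cannot be told apart from compound 1, at 15600 nM, since the two values lie within the usual scatter of repeated measurements. Compound 2, at 74200 nM, has a higher number than compound 3, by a gap beyond that scatter, and so is the weaker inhibitor of the two.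

The next compound to be tested is compound 4 `COc1ccc(-c2nc3cc(F)ccc3s2)cc1Br`. It is compound 3 with bromo in place of methyl on an aromatic carbon, ortho to a methoxy group: bromo in place of methyl on an aromatic carbon. Within the data shown here, no two measured compounds differ in one place only, so the data hold no direct precedent for this swap. One heavy atom replaces one heavy atom, and the rest of the structure stays the same, so only a small change is expected. The expected 1.2-fold lower number from compound 3 to compound 4 (0.09 log units; within the scatter) stays within the scatter, with no firm direction. For compound 4 the estimated value is 15000 nM, with an expected range of 5000 nM to 50000 nM.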

Compound 4, concentration for 50% growth inhibition: 6700 nM
The estimate for compound 4 lay 2.2-fold (0.35 log units) above the measured number; the measured number falls inside the stated range.
By their numbers in this assay, from the lowest: compound 4; then compounds 1 and 3 (each within the scatter of the next); then compound 2.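

Measured in this assay the swap of methyl for bromo, on the aromatic carbon ortho to a methoxy group, gives a 2.8-fold lower number from compound 3 to compound 4 (0.44 log units; beyond the scatter) and so counts as a modest step that lies beyond the scatter. Among these compounds, this is the first pair here that differs in one place only, and it shows that this position responds to a change of a single heavy atom, with bromo giving the stronger inhibitor of growth of the two. Nothing available explains why this swap lowers the number.

One step cannot show how other groups would behave at this position, such as chloro, an amine or a longer chain. It also leaves open whether bromo would give a similar step on a compound that differs elsewhere, such as one without the fluoro group.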